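4-Methoxyphenyl to 4-nitrophenyl on the shared core

The source may report more compounds than this note shows. Statements on the series, on what has been measured and on what is new or still open speak of the compounds shown alone.

In a functional assay on Bel-7402 cells (Homo sapiens) for cytotoxicity, read by MTT assay, with a stated time of 72 h (on this read-out lower numbers stand for stronger inhibition and higher numbers for weaker inhibition), compound 1 (`C=C1C(=O)[C@@]23C(=O)OC[C@]4(C(=O)CCC(C)(C)[C@H]4C=O)[C@@H]2CC[C@@H]1[C@H]3OC(C)=O`) stands at 1730 nM and compound 2 (`C=C1C(=O)[C@@]23C(=O)OC[C@]4(C(=O)CCC(C)(C)[C@H]4C=O)[C@@H]2CC[C@@H]1[C@H]3OC(=O)c1ccccc1`) at 1850 nM while compound 3 (`C=C1C(=O)[C@@]23C(=O)OC[C@]4(C(=O)CCC(C)(C)[C@H]4C=O)[C@@H]2CC[C@@H]1[C@H]3OC(=O)c1ccc(OC)cc1`) stands at 2800 nM with all three inside the scatter of one another. Compound 3 is not separated from either of the others (a 1.5-fold higher number from compound 2 to compound 3 (0.18 log units; within the scatter) and a 1.6-fold higher number from compound 1 to compound 3 (0.21 log units; within the scatter)).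

Compound 4 (`C=C1C(=O)[C@@]23C(=O)OC[C@]4(C(=O)CCC(C)(C)[C@H]4C=O)[C@@H]2CC[C@@H]1[C@H]3OC(=O)c1ccc([N+](=O)[O-])cc1`) differs from compound 3 in one group (nitro in place of methoxy on an aromatic carbon) with nitro in place of methoxy on an aromatic carbon, para to a large group. Among the measured compounds shown here, no measured step brings in a nitro group. The closest measured step is methoxy in place of hydrogen on an aromatic carbon (a 1.5-fold higher number from compound 2 to compound 3 (0.18 log units; within the scatter)), and phenyl in place of methyl on a carbonyl carbon also bears on it (a 1.1-fold higher number from compound 1 to compound 2 (0.03 log units; within the scatter)). Neither leaves the scatter.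

A step beyond the scatter in this assay is therefore not expected, and the estimated change is small (a 1.3-fold lower number from compound 3 to compound 4 (0.10 log units; within the scatter)). For compound 4 the expected value is 2200 nM with an estimated range from 1000 nM to 5000 nM on this read-out.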

Compound 4, half-maximal inhibitory concentration: 3300 nM
Compound 4: middle estimate off by 1.5-fold (0.18 log units), on the low side; low and high end bracket the measured number.
By their numbers in this assay, from the lowest: compounds 1, 2, 3 and 4 (each within the scatter of the next).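

In this assay, nitro in place of methoxy on this aromatic carbon, para to a large group, gives no separation (a 1.2-fold higher number from compound 3 to compound 4 (0.07 log units; within the scatter)), although nitro brings more heavy atoms and hydrogen-bond acceptors than methoxy. Nitro in place of hydrogen also stays within the scatter (a 1.8-fold higher number from compound 2 to compound 4 (0.25 log units; within the scatter)), as does 4-nitrophenyl in place of methyl on a carbonyl carbon (a 1.9-fold higher number from compound 1 to compound 4 (0.28 log units; within the scatter)). Among the compounds shown here, with nitro added, no step among the four compounds leaves the scatter, so this position shows no separated change for hydrogen, methoxy or nitro on the aromatic ring, or for methyl in place of that ring.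

From the compounds shown here alone, whether an amine or a carboxylic acid on the same aromatic carbon would leave the scatter remains open. No available evidence bears on why these four values stay so close.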